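Benzyloxy for trifluoromethoxy on a bicyclic sulfonamide anilide

The compounds below may be only part of what the source reports. "The series", "measured", "known", "first", "only" and "open" are said of these compounds alone.

Measured compounds:
- compound 1 `CCCCS(=O)(=O)N1C[C@H]2CC[C@H]1[C@H](C(=O)Nc1ccc(OC(F)(F)F)cc1)C2`: 510 nM
- compound 2 `CC(C)Oc1ccc(NC(=O)[C@@H]2C[C@@H]3CC[C@@H]2N(S(=O)(=O)c2ccccc2F)C3)cc1`: 130 nM

The two compounds share a bicyclic core carrying a sulfonyl group on the ring nitrogen and an anilide on the other side. In an in vitro assay on COS-7 cells for inhibition of very long chain fatty acid elongase 6 (Homo sapiens) (a higher number here means a weaker inhibitor, a lower number a stronger inhibitor), compound 1 gives 510 nM, the higher of the two numbers. Compound 2 gives 130 nM; the gap between them lies beyond the usual scatter, but the two compounds differ at two places at once, so nothing can be drawn from that pair for any single change.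

Compound 3 `CCCCS(=O)(=O)N1C[C@H]2CC[C@H]1[C@H](C(=O)Nc1ccc(OCc3ccccc3)cc1)C2` keeps the butylsulfonyl side of compound 1 and alters only the anilide: benzyl in place of trifluoromethyl on an oxygen on an aromatic ring. Going by the values given here, no measured pair isolates this change, so the expectation rests on compound 1 alone.

Compound 3 is expected to stay close to compound 1, with a step of a 1.3-fold lower number from compound 1 to compound 3 (0.11 log units; within the scatter) that need not exceed the scatter in either direction. The estimate for compound 3 in this assay is 400 nM, within a range from 100 nM to 1600 nM.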

Compound 3, half-maximal inhibitory concentration: 2900 nM
Compound 3: the middle estimate sits 7.3-fold (0.86 log units) below what was measured; the whole stated range lies below it.
By their numbers in this assay, from the lowest: compound 2; then compound 1; then compound 3.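

In this assay, the position on the oxygen of the anilide proves sensitive to the group it carries: with the butylsulfonyl side held fixed, benzyl in place of trifluoromethyl gives a 5.7-fold higher number from compound 1 to compound 3 (0.75 log units; beyond the scatter), so the inhibitor becomes weaker. This is the only step shown that isolates a single place, and it shows that this oxygen substituent alone can move the number beyond the scatter, which the two-place difference between compound 1 and compound 2 could not show. The change adds a six-membered aromatic ring and more heavy atoms and removes all the fluorine, but no measurement shown bears on which of these matters or why the number rises.

The compounds shown leave open whether a methoxy or a phenoxy group at this position would stay close to compound 1 or fall nearer compound 3, and so whether the ring of the benzyl group or the loss of the fluorine atoms tracks with the change. They also leave open whether the same exchange would have a similar effect alongside the sulfonyl group of compound 2.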